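The source may hold more compounds than are shown below. What is called first, only, known or untested is meant among the compounds shown, and "the series" means these compounds.

Of the compounds shown here, two sharing one core have so far been measured in an assay on isolated protein for inhibition of CAAX prenyl protease 2 (Homo sapiens), with stated times of 60 s and 60 min; a higher number here means a weaker inhibitor, a lower number a stronger inhibitor. Compound 1 `N#Cc1ccc(C(Nc2ccc(C(=O)O)cc2)c2ccc3cccnc3c2O)cc1` carries a cyano group and in this assay gives 16000 nM. Compound 2 `Cc1ccc(C(Nc2ccc(C(=O)O)cc2)c2ccc3cccnc3c2O)cc1` carries a methyl group in its place and in this assay gives 7100 nM. Among the compounds with values here, the single step between them, a 2.3-fold lower number from compound 1 to compound 2 (0.35 log units; beyond the scatter), is modest but beyond the scatter. Compound 2 therefore stands with the lower of the two numbers and is the stronger inhibitor of the pair.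

Compound 3 `O=C(O)c1ccc(NC(c2ccc(Br)cc2)c2ccc3cccnc3c2O)cc1` has not yet been measured. It differs from compound 2 in one place: bromo in place of methyl on an aromatic carbon. Within the data shown here, no measured step swaps methyl for bromo, so only the step from compound 1 to compound 2 bears on it, and only loosely, as it shows that exchanging this one group shifts the number by a modest amount. A step of similar size or smaller is expected in this assay, with no clear direction. Compound 3 is therefore estimated at 5500 nM, within a range from 2000 nM to 15000 nM. The expected step, a 1.3-fold lower number from compound 2 to compound 3 (0.11 log units; within the scatter), is small.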

Compound 3, half-maximal inhibitory concentration: 6700 nM
Compound 3: middle estimate off by 1.2-fold (0.09 log units), on the low side; the range from low to high includes it.
By their numbers in this assay, from the lowest: compounds 3 and 2 (each within the scatter of the next); then compound 1.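

On this aromatic carbon, para to a large group, replacing methyl with bromo in this assay gives a 1.1-fold lower number from compound 2 to compound 3 (0.03 log units; within the scatter) and so leaves the number effectively unchanged, even though one carbon has been exchanged for one bromine. Replacing the cyano group of compound 1 with bromo gives a 2.4-fold lower number from compound 1 to compound 3 (0.38 log units; beyond the scatter) and shows that the earlier gain is not unique to methyl: among these three compounds, the two carrying methyl and bromo cannot be separated, while the cyano compound stands apart with the higher number. Nothing measured here explains why these groups compare in this way.

The compounds shown leave open whether an amine, a methoxy group or a longer chain at this position would shift the number by more than these modest steps, or in the opposite direction. They also leave open whether changes elsewhere on the shared core, such as an amide in place of the carboxylic acid, would alter the number more than changes at this position do.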